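The source may hold more compounds than are shown below. What is called first, only, known or untested is meant among the compounds shown, and "the series" means these compounds.

Compound 2 `N#C/C(=C\c1ccco1)C(=O)NCc1ccc(Cl)c(Cl)c1` is the starting point. In a functional assay on BE(2)-C cells (Homo sapiens) for inhibition, read by MTT assay, with a stated time of 72 h (on this read-out lower numbers stand for stronger inhibition of growth and higher numbers for weaker inhibition of growth), compound 2 reaches > 50000 nM, which is a limit of the assay rather than a number. Compound 1 `N#C/C(=C\c1ccc[nH]1)C(=O)NCc1ccc(Cl)c(Cl)c1` gives 43000 nM in this assay, and compound 3 `COc1ccc(CNC(=O)/C(C#N)=C/c2cccc3ccccc23)cc1` gives 14000 nM. Within the data shown here, the one measured step, an at least 1.1-fold higher number from compound 1 to compound 2 (0.06 log units; that floor lies within the scatter), is an at-least figure because compound 2 sits at the limit of > 50000 nM in this assay, at which 1 of the 3 values shown sits. Compound 4 `N#C/C(=C\c1ccccc1)C(=O)NCc1ccc(Cl)c(Cl)c1` arises through the change (phenyl in place of furan-2-yl on a double-bonded chain carbon bound to a double-bonded chain carbon). Among the measured compounds shown here, no measured step swaps an aromatic five-membered ring for phenyl at that place, so only a weak shift from compound 2 is expected, estimated as an at least 1.2-fold lower number from compound 2 to compound 4 (0.09 log units; that floor lies within the scatter). Compound 4 is therefore expected to give about 40000 nM in this assay, most likely between 15000 nM and 100000 nM.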

Compound 4, concentration for 50% growth inhibition: 32000 nM
Compound 4: middle estimate off by 1.3-fold (0.10 log units), on the high side; measured number inside the range.
By their numbers in this assay, from the lowest: compound 3; then compounds 4 and 1 (each within the scatter of the next). At a limit, above all of these: compound 2.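

Phenyl at this place on a double-bonded chain carbon gives the first measured number for a six-membered aromatic ring there. Replacing 1H-pyrrol-2-yl with phenyl gives a 1.3-fold lower number from compound 1 to compound 4 (0.13 log units; within the scatter), so these two rings cannot be told apart in this assay. Replacing furan-2-yl with phenyl gives an at least 1.5-fold lower number from compound 2 to compound 4 (0.19 log units; that floor lies within the scatter), and this is only a floor because compound 2 sits at a limit: the limit of > 50000 nM in this assay, at which 1 of the 4 values shown sits.

On these data alone, what a pyridine ring, or a phenyl carrying an amine or a carboxylic acid, would give at this place stays open. Compound 3 differs from compound 4 in more than one place, so that pair isolates no single change.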